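Shortening a Sulfur-Linked Chain: From Compound 3 to Compound 4

This account rests on a few compounds, and the source may have more. Where it says the series, first, only, none or still open, it means among the compounds named here.

Three related compounds share one core carrying sulfur- or selenium-linked groups. For compound 1 `C[Se]c1nc([Se]C)c2cccnc2n1` the result in a functional assay on MCF7 cells (Homo sapiens) for cytotoxicity, read by MTT assay, with a stated time of 72 h (on this read-out higher numbers stand for weaker inhibition of growth and lower numbers for stronger inhibition of growth), is "not determined" (no result reported). Compound 2 `CCCCC[Se]c1nc([Se]CCCCC)c2ccccc2n1` gives 38400 nM in this assay. Compound 3 `CCCCCSc1nc(NCc2ccc([Se]C)cc2)c2ccccc2n1`, which carries a pentylsulfanyl group, gives 13000 nM in this assay. Of the two numbers available, compound 3 has the lower one, and its gap to compound 2 lies beyond the usual scatter of repeated measurements. The two structures differ in several places at once, and nothing more is read from that pair.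

Compound 4 `CSc1nc(NCc2ccc([Se]C)cc2)c2ccccc2n1` keeps everything in compound 3 except the chain on the sulfur. The change is hydrogen in place of butyl on a saturated chain carbon bound to a sulfur, so that pentylsulfanyl becomes methylsulfanyl. No measured pair among these compounds shows this kind of chain shortening, so the size of the step cannot be taken from the data. The expectation is a small weakening or no change beyond the scatter. The expected step is a 1.5-fold higher number from compound 3 to compound 4 (0.19 log units; within the scatter). For compound 4 the estimated value in this assay is 20000 nM, with a plausible range from 6000 nM to 60000 nM.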

Compound 4, concentration for 50% growth inhibition: 36400 nM
For compound 4 the middle estimate is 1.8-fold (0.26 log units) below the measured one; measured number inside the range.
By their numbers in this assay, from the lowest: compound 3; then compounds 4 and 2 (each within the scatter of the next).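

In this assay the shortening of pentylsulfanyl to methylsulfanyl gives a 2.8-fold higher number from compound 3 to compound 4 (0.45 log units; beyond the scatter) and is the first change at a single place that can be read among these compounds. The step is modest but lies beyond the scatter, so the chain on the sulfur is not a neutral spot: with everything else in the molecule held the same, the longer pentyl chain goes with stronger inhibition of growth and the methyl chain with weaker inhibition. No measurement at hand offers an explanation for this difference, so the pair records the size and direction of the step and nothing about its cause.

Only pentyl and methyl are shown on this sulfur, so it remains open how a propyl chain would fall relative to them and whether a longer chain such as heptyl would lower the number further. Also open, on these data alone, is how a chain ending in an amine or a carboxylic acid would compare with these plain chains, and whether the same shortening would give a similar step with selenium in place of the sulfur.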